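Cyano in place of 2-acetylethyl: compound 3 awaits measurement

The source may hold more compounds than are shown below. What is called first, only, known or untested is meant among the compounds shown, and "the series" means these compounds.

Among the measured compounds shown here, in a physicochemical assay for solubility, with a stated time of 4 h, at pH 2.0 (a higher number here means a more soluble compound, a lower number a less soluble compound), compound 1 `CC(=O)CCc1cc(C)c(Oc2cc(Nc3ccc(C#N)cc3)c(N)cc2C(F)(F)F)c(C)c1` gives 0.28 ug/mL as the lower of two numbers so far, while compound 2 `CNC(=O)c1cc(N)c(Nc2ccc(C#N)cc2)cc1Oc1c(C)cc(CCC#N)cc1C` gives 44.7 ug/mL on the higher side, beyond the scatter. Compound 3 `Cc1cc(C#N)cc(C)c1Oc1cc(Nc2ccc(C#N)cc2)c(N)cc1C(F)(F)F` differs from compound 1 by cyano in place of 2-acetylethyl on an aromatic carbon and has not yet been measured. For the measured compounds named here, no measured pair shows this change, so only a small rise is expected in this assay and it may stay within the scatter. The expected change is a 1.4-fold higher number from compound 1 to compound 3 (0.15 log units; within the scatter) by this estimate. Compound 3 is estimated at 0.4 ug/mL with a range from 0.1 ug/mL to 2 ug/mL expected for the measurement.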

Compound 3, solubility: 0.96 ug/mL
Compound 3: the middle estimate sits 2.4-fold (0.38 log units) below what was measured; the range from low to high includes it.
By their numbers in this assay, from the lowest: compound 1; then compound 3; then compound 2.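

In this assay, the place para to a large group and meta to two methyl groups proves responsive: cyano in place of 2-acetylethyl gives a 3.4-fold higher number from compound 1 to compound 3 (0.54 log units; beyond the scatter) on the core of compound 1. The group that leaves has 5 heavy atoms and the one that enters has 2, while each has 1 hydrogen-bond acceptor and no donor. Nothing available accounts for this rise. Going by these compounds, whether an amine, a carboxylic acid or a longer chain at this place would give a higher number remains open, as does whether the step carries over to other cores.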